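The source may report more compounds than this note shows. Statements on the series, on what has been measured and on what is new or still open speak of the compounds shown alone.

Measured in a functional assay on MC-38 cells (Mus musculus) for antiproliferative activity, read by CCK-8 assay, with a stated time of 72 h; on this read-out lower numbers stand for stronger inhibition of growth and higher numbers for weaker inhibition of growth:
- compound 1 `Nc1nc(NCc2ccc(OCCCCC(=O)NO)cc2)nc2nc(-c3ccco3)nn12` gives "not determined" (no result reported) as its entry
- compound 2 `Nc1nc(NCCCc2ccc(C(=O)NO)cc2)nc2nc(-c3ccco3)nn12` gives > 100000 nM as its entry

Compound 2 gives > 100000 nM as a limit of the assay and not a number. Within the data shown here, compound 1 has no result, so no ranking of the two is possible, and no step between measured compounds exists.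

The next compound is compound 3 `Nc1ccccc1NC(=O)c1ccc(CCCNc2nc(N)n3nc(-c4ccco4)nc3n2)cc1`, still unmeasured. It is derived from compound 2 by one change, (2-aminophenyl in place of hydroxy on an amide-type nitrogen), which in words places 2-aminophenyl in place of hydroxy on an amide-type nitrogen, so that hydroxycarbamoyl becomes (2-aminophenyl)carbamoyl.

Among the measured compounds shown here, with no measured step to lean on, the expectation rests on compound 2 alone and is loose. The expected at least 2.5-fold lower number from compound 2 to compound 3 (0.39 log units; beyond the scatter) is towards stronger inhibition of growth, but only modestly, and a further result reported only as a limit would not be surprising. Compound 3 is estimated at 40000 nM with an expected range from 8000 nM to 100000 nM as the working figure.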

Compound 3, concentration for 50% growth inhibition: 25400 nM
The estimate for compound 3 lay 1.6-fold (0.20 log units) above the measured number; low and high end bracket the measured number.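

In this assay, the amide-type nitrogen of the hydroxycarbamoyl group now has a first readable change: 2-aminophenyl in place of hydroxy gives an at least 3.9-fold lower number from compound 2 to compound 3 (0.59 log units; beyond the scatter) as the step. With compound 3 at 25400 nM, the series has its first actual number on this read-out, and the (2-aminophenyl)carbamoyl form gives growth inhibition that can be quantified, although only at a high concentration compared with the range a reader might hope for in a lead. The step is a lower bound and not a true size, as compound 2 gives only a limit of the assay, with no number behind it: the limit of > 100000 nM in this assay, at which 1 of the 3 values shown sits.

As far as these compounds go, the true distance between the hydroxycarbamoyl and (2-aminophenyl)carbamoyl forms stays open, as does the part played by the amino group of the 2-aminophenyl ring. A plain phenyl on the same nitrogen, or a carboxylic acid in place of the whole hydroxycarbamoyl group, would be needed to separate the contribution of the ring from that of its amino group and to show how much of the step belongs to each.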